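Cytotoxicity notes: cyclopentyl for aryl at the ring nitrogen

The source may hold more compounds than are shown below. What is called first, only, known or untested is meant among the compounds shown, and "the series" means these compounds.

In an ADME assay on HT-29 cells (Homo sapiens) for cytotoxicity, read by MTT assay, with a stated time of 72 h (a higher number here means a weaker inhibitor, a lower number a stronger inhibitor), compound 3 `C=CC(=O)Nc1cc(Nc2ncc3ncn(-c4ccccc4F)c3n2)c(OC)cc1N(C)CCN(C)C` gives 9750 nM, the highest number shown, though compound 1 `C=CC(=O)Nc1cc(Nc2ncc3ncn(-c4ccc(C)cc4)c3n2)c(OC)cc1N(C)CCN(C)C`, which gives 9230 nM, sits within the scatter of it. Compound 2 `C=CC(=O)Nc1cc(Nc2ncc3ncn(-c4ccc(Br)cc4)c3n2)c(OC)cc1N(C)CCN(C)C` gives 1460 nM. The steps touching this position run a 1.1-fold higher number from compound 1 to compound 3 (0.02 log units; within the scatter), a 6.7-fold higher number from compound 2 to compound 3 (0.82 log units; beyond the scatter) and a 6.3-fold lower number from compound 1 to compound 2 (0.80 log units; beyond the scatter). Compound 4 `C=CC(=O)Nc1cc(Nc2ncc3ncn(C4CCCC4)c3n2)c(OC)cc1N(C)CCN(C)C` differs from compound 3 by cyclopentyl in place of 2-fluorophenyl on an aromatic nitrogen. Both measured steps at this nitrogen exchange one aryl group for another; none exchanges an aryl group for a non-aromatic ring, so they bear only loosely on this change. Compound 1 and compound 3 agree within the scatter while compound 2 stands apart. For compound 4 a step within the scatter is expected, a 1.2-fold lower number from compound 3 to compound 4 (0.09 log units; within the scatter). Compound 4 is estimated at 8000 nM, with a range from 2500 nM to 25000 nM.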

Compound 4, half-maximal inhibitory concentration: 20900 nM
The estimate for compound 4 lay 2.6-fold (0.42 log units) below the measured number; the range from low to high includes it.
By their numbers in this assay, from the lowest: compound 2; then compounds 1 and 3 (each within the scatter of the next); then compound 4.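

In this assay cyclopentyl on the aromatic nitrogen gives a higher number than each aryl group shown: a 2.1-fold higher number from compound 3 to compound 4 (0.33 log units; beyond the scatter) and a 2.3-fold higher number from compound 1 to compound 4 (0.35 log units; beyond the scatter) and a 14-fold higher number from compound 2 to compound 4 (1.16 log units; beyond the scatter) as the largest step. Leaving the aromatic ring at this nitrogen therefore registers beyond the scatter, whichever aryl group is replaced. No measurement shown here accounts for these steps.

From the compounds shown here alone, whether a cyclohexyl ring or a piperidine ring would follow cyclopentyl remains open. So does whether an open alkyl chain at this nitrogen would give a similar number.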